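This account rests on a few compounds, and the source may have more. Where it says the series, first, only, none or still open, it means among the compounds named here.

Measured in a functional assay on MV4-11 cells (Homo sapiens) for inhibition, read by luminescence, with a stated time of 72 h; a higher number here means a weaker inhibitor, a lower number a stronger inhibitor:
Compound 1 `CC(=O)c1c(C)c2ccc(Nc3nccc(-c4cccnc4)n3)cc2oc1=O`: 12900 nM
Compound 2 `CCN1CCN(Cc2cc(Nc3ncc(F)c(-c4ccc(F)cc4OC)n3)cc3c2OCC(=O)N3CC)CC1`: 142 nM

Of these two compounds, compound 2 has the lower number and so is the stronger inhibitor. Compound 2 gives 142 nM and compound 1 gives 12900 nM. The gap between these two values lies beyond the scatter. The next compound, compound 3 `CCN1C(=O)COc2c(CN3CCN(C(C)C)CC3)cc(Nc3ncc(F)c(-c4ccc(F)cc4OC)n3)cc21`, has not yet been measured. It differs from compound 2 in one place: methyl in place of hydrogen on a saturated chain carbon bound to an amine nitrogen in a ring and a saturated chain carbon. This puts methyl in place of hydrogen on a saturated chain carbon bound to an amine nitrogen in a ring and a saturated chain carbon, turning 4-ethylpiperazin-1-yl into 4-isopropylpiperazin-1-yl. Going by the values given here, no measured pair shows the effect of such a change in this assay, so no direction is favoured, and a shift within the scatter is expected. The expected step is a 1.1-fold higher number from compound 2 to compound 3 (0.02 log units; within the scatter). For compound 3 the estimated value is 150 nM, with a range of 50 nM to 450 nM.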

Compound 3, half-maximal inhibitory concentration: 149 nM
Compound 3: the middle estimate sits 1.0-fold (0.00 log units) above what was measured; low and high end bracket the measured number.
By their numbers in this assay, from the lowest: compounds 2 and 3 (each within the scatter of the next); then compound 1.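

In this assay, going by these compounds alone, the pair gives the first direct reading of a single change: methyl in place of hydrogen on a saturated chain carbon bound to an amine nitrogen in a ring and a saturated chain carbon, with a 1.0-fold higher number from compound 2 to compound 3 (0.02 log units; within the scatter). Turning 4-ethylpiperazin-1-yl into 4-isopropylpiperazin-1-yl therefore leaves the number within the scatter, so this added methyl has no readable effect on this core in this assay. Nothing in the data shown explains this result. 

On these data alone, this one pair cannot show how far the result extends, and whether a longer chain such as n-butyl, a cyclopropyl ring or a hydroxyethyl group in place of the ethyl of compound 2 would behave alike remains open. Also open, as far as these compounds go, is how a plain hydrogen on that piperazine nitrogen would read in this assay.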